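Sulfonyl substituent variation in the hydroxy-trifluoromethyl amide series

The compounds below may be only part of what the source reports. "The series", "measured", "known", "first", "only" and "open" are said of these compounds alone.

Compound 1 `CC(O)(C(=O)Nc1ccc(S(=O)(=O)c2ccc(C#N)cc2)cc1)C(F)(F)F` carries a 4-cyanophenyl on the sulfonyl sulfur. In a functional assay (Cavia porcellus) with sulfonylurea receptors; K-ATP channels (Homo sapiens) as the target (on this read-out lower numbers stand for stronger inhibition and higher numbers for weaker inhibition), compound 1 gives only a limit, > 30000 nM. Compound 1 thus sits at the limit of > 30000 nM in this assay, at which 1 of the 3 values shown sits. Compound 2 `CC(O)(C(=O)Nc1ccc(S(=O)(=O)c2ccccc2O)cc1)C(F)(F)F` gives 3090 nM in this assay, and compound 3 `CC(O)(C(=O)Nc1ccc(S(=O)(=O)c2ccccc2Cl)cc1)C(F)(F)F` gives 2300 nM. These two are separated by a 1.3-fold lower number from compound 2 to compound 3 (0.13 log units; within the scatter), so compound 3 stands together with compound 2 among the measured numbers, with no separation between them that can be trusted. The two steps that exchanged the group on the sulfonyl sulfur, an at least 9.7-fold lower number from compound 1 to compound 2 (0.98 log units; beyond the scatter) and an at least 13-fold lower number from compound 1 to compound 3 (1.11 log units; beyond the scatter), both carried the number from the limit down to a measured value.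

Compound 4 `CN(c1ccccc1)S(=O)(=O)c1ccc(NC(=O)C(C)(O)C(F)(F)F)cc1` differs from compound 3 by methyl(phenyl)amino in place of 2-chlorophenyl on a sulfonyl sulfur. The measured steps only swap one substituted phenyl on the sulfonyl sulfur for another; none exchanges such a phenyl for an amino group, so they set only a loose frame for this change. Given that both earlier exchanges at this position produced large movements, a step beyond the scatter is expected for this assay, and with no precedent for the new group the direction is taken as toward a higher number, as a 2.6-fold higher number from compound 3 to compound 4 (0.42 log units; beyond the scatter). Compound 4 is estimated at 6000 nM, within a range from 1200 nM to 30000 nM.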

Compound 4, half-maximal inhibitory concentration: 2000 nM
For compound 4 the middle estimate is 3.0-fold (0.48 log units) above the measured one, and the stated range covers the measured number.
By their numbers in this assay, from the lowest: compounds 4, 3 and 2 (each within the scatter of the next). At a limit, above all of these: compound 1.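

Exchanging the group on the sulfonyl sulfur for one attached through nitrogen leaves the number in place within the scatter, as a 1.2-fold lower number from compound 3 to compound 4 (0.06 log units; within the scatter) and a 1.5-fold lower number from compound 2 to compound 4 (0.19 log units; within the scatter) show. In this assay, this position therefore accepts methyl(phenyl)amino alongside 2-chlorophenyl and 2-hydroxyphenyl, so among the compounds shown a phenyl directly on the sulfonyl sulfur is not required for a measured value. For the compounds shown here, the third step, an at least 15-fold lower number from compound 1 to compound 4 (1.17 log units; beyond the scatter), starts from a limit and is of the same kind as the earlier steps away from 4-cyanophenyl, so compound 1 remains the only compound set apart from the others.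

Nothing shown gives a measured property that bears on the separation of compound 1 from the other three compounds. On these data alone, it remains open whether the phenyl or the methyl of methyl(phenyl)amino matters at this position, as a dimethylamino group or an unsubstituted phenylamino group would test, and whether a cyclic amine such as morpholine or piperidine on the sulfonyl sulfur would stand with compound 4.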